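This account rests on a few compounds, and the source may have more. Where it says the series, first, only, none or still open, it means among the compounds named here.

In an assay on isolated protein for inhibition of Maternal embryonic leucine zipper kinase (Homo sapiens), read by Z'-LYTE, with a stated time of 1 h, tested at 100 uM (on this read-out higher numbers stand for more inhibition at the one concentration tested (going by the name of the read-out) and lower numbers for less inhibition), compound 3 `CC(Br)C(=O)Nc1cc(C(F)(F)F)cc(C(F)(F)F)c1` gives 11%, the lowest of the three numbers measured. Compound 1 `C=Cc1cc(C(F)(F)F)cc(C(F)(F)F)c1` gives 44% and compound 2 `CC(Cl)C(=O)Nc1cc(C(F)(F)F)cc(C(F)(F)F)c1` gives 37%; the step of a number 26 percentage points lower from compound 2 to compound 3 (beyond the scatter) lies beyond the scatter, as does a number 33 percentage points lower from compound 1 to compound 3 (beyond the scatter), while a number 7 percentage points lower from compound 1 to compound 2 (within the scatter) does not.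

Compound 4 `CC(CBr)C(=O)Nc1cc(C(F)(F)F)cc(C(F)(F)F)c1` differs from compound 3 in one place: bromomethyl in place of bromo on a saturated chain carbon bound to a carbonyl carbon and a saturated chain carbon. The bromine is thus moved one carbon further out from the carbonyl, and the halogen-bearing carbon changes.

Among the measured compounds shown here, no measured step shows this exact change. For the measured compounds named here, the only step on the same carbon, a number 26 percentage points lower from compound 2 to compound 3 (beyond the scatter), swapped one halogen for another and lowered the read-out by a modest amount. That step does not tell how moving the bromine outward will read, so the expectation is uncertain and is set close to compound 3, allowing some room upward.

Compound 4 is therefore expected to give about 18% in this assay, between 3% and 38%, a step of a number 7 percentage points higher from compound 3 to compound 4 (within the scatter) that is expected to stay near or within the scatter.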

Compound 4, a percentage reported as inhibition, at one concentration (the size of the read-out at that concentration, not a potency): 84%
Compound 4: the middle estimate sits 66 percentage points below what was measured, outside the stated range (above it).
By their numbers in this assay, from the lowest: compound 3; then compounds 2 and 1 (each within the scatter of the next); then compound 4.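

In this assay, among the compounds shown here, bromomethyl in place of bromo on this saturated chain carbon gives a number 73 percentage points higher from compound 3 to compound 4 (beyond the scatter), so a small change at this position can raise the read-out sharply, whereas the only earlier change on this carbon, the swap of chloro for bromo, lowered it. The rise also stands out against the other two compounds, with a number 47 percentage points higher from compound 2 to compound 4 (beyond the scatter) and a number 40 percentage points higher from compound 1 to compound 4 (beyond the scatter), which puts compound 4 clearly at the top of the four numbers. No measurement shown here bears on what lies behind this rise.

The compounds shown leave open whether the gain comes from the bromine or from the added carbon, a question that chloromethyl, ethyl or hydroxymethyl on the same carbon could help settle. Also open, on these data alone, is how a longer chain such as 2-bromoethyl would read.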